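The source may report more compounds than this note shows. Statements on the series, on what has been measured and on what is new or still open speak of the compounds shown alone.

Compound 1 `CCCC1=C(OC)C(CCC)(CCC)C(=O)/C(=C(O)\C=C\c2ccc(I)cc2)C1=O`: 1.1 uM
Compound 2 `CCCOC1=C(CCC)C(=O)/C(=C(O)/C=C/c2ccccc2)C(=O)C1(CCC)CCC`: 2.6 uM

In a functional assay on HCT-8 cells (Homo sapiens) for antiproliferative activity, read by sulforhodamine B assay, with a stated time of 3 days (a lower number here means that less compound is needed, a higher number that more compound is needed for the effect), compound 2 has the higher of the two numbers, and compound 1 at 1.1 uM lies lower by more than the usual scatter. Compound 3 `CCCOC1=C(CCC)C(=O)/C(=C(O)/C=C/c2ccc(I)cc2)C(=O)C1(CCC)CCC` is compound 2 with a single change: iodo in place of hydrogen on an aromatic carbon. Going by the values given here, compound 1 also carries a 4-iodophenyl group and gives 1.1 uM, so a modest move to a lower number is expected, although no measured pair isolates this change. The expected change is a 2.0-fold lower number from compound 2 to compound 3 (0.30 log units; within the scatter). For compound 3 the estimated value is 1.3 uM, with an expected range of 0.5 uM to 3.2 uM.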

Compound 3, concentration for half-maximal effect: 7.8 uM
Compound 3: the middle estimate sits 6.0-fold (0.78 log units) below what was measured; measured number outside the range, above it.
By their numbers in this assay, from the lowest: compound 1; then compound 2; then compound 3.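

In this assay, putting iodo on the aromatic ring gives a 3.0-fold higher number from compound 2 to compound 3 (0.48 log units; beyond the scatter), so on this compound pair the change raises the number instead of lowering it. With the 4-iodophenyl group kept, ethyl in place of hydrogen on the chain carbon bound to oxygen gives a 7.1-fold higher number from compound 1 to compound 3 (0.85 log units; beyond the scatter), so the low value of compound 1 cannot be credited to iodo alone. Nothing measured here explains either step. Still open, on these data alone, is how fluoro or an amine would behave at this ring position, and whether the ethyl step also holds on the unsubstituted phenyl.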